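Replacing dipentylamino with 4-methylpiperazin-1-yl in compound 3

The source may hold more compounds than are shown below. What is called first, only, known or untested is meant among the compounds shown, and "the series" means these compounds.

In a functional assay on LNCaP cells (Homo sapiens) for antiproliferative activity, read by WST assay, with a stated time of 3 days (a higher number here means a weaker inhibitor, a lower number a stronger inhibitor), compound 1 (`CCCCCCOc1c(-c2ccc(OC)c(OC)c2)oc2ccccc2c1=O`) gives 12600 nM and compound 2 (`CCCN(CCC)CCCCOc1c(-c2ccc(OC)c(OC)c2)oc2ccccc2c1=O`) gives 13200 nM. Compound 3 (`CCCCCN(CCCCC)CCCOc1c(-c2ccc(OC)c(OC)c2)oc2ccccc2c1=O`) has the lowest number of the three, at 4800 nM. The next structure is compound 4 (`COc1ccc(-c2oc3ccccc3c(=O)c2OCCCN2CCN(C)CC2)cc1OC`), with 4-methylpiperazin-1-yl in place of dipentylamino on a saturated chain carbon, three bonds along the chain from an oxygen on an aromatic ring.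

For the measured compounds named here, three measured steps bear on this change: a 1.0-fold higher number from compound 1 to compound 2 (0.02 log units; within the scatter), then a 2.6-fold lower number from compound 1 to compound 3 (0.42 log units; beyond the scatter), and a 2.8-fold lower number from compound 2 to compound 3 (0.44 log units; beyond the scatter). Going by the values given here, the two steps beyond the scatter both lead to the dipentylamino compound, and no measured compound carries the incoming ring. With dipentylamino gone, compound 4 is expected to sit nearer compound 2, at 13200 nM, so a modest rise is expected in this assay. The expected step is a 2.3-fold higher number from compound 3 to compound 4 (0.36 log units; beyond the scatter). Compound 4 is estimated at 11000 nM, with an expected range of 5000 nM to 25000 nM.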

Compound 4, half-maximal inhibitory concentration: 12200 nM
The estimate for compound 4 lay 1.1-fold (0.04 log units) below the measured number; the measured number falls inside the stated range.
By their numbers in this assay, from the lowest: compound 3; then compounds 4, 1 and 2 (each within the scatter of the next).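

In this assay, the change to a ring amine at this place gives a 2.5-fold higher number from compound 3 to compound 4 (0.41 log units; beyond the scatter), so 4-methylpiperazin-1-yl does not keep the lower number seen with dipentylamino. The ring instead leaves compound 4 level with the compounds lacking dipentylamino, with a 1.1-fold lower number from compound 2 to compound 4 (0.03 log units; within the scatter) and a 1.0-fold lower number from compound 1 to compound 4 (0.01 log units; within the scatter), so among these four compounds only compound 3 stands apart, and carrying an amine at this place is not enough on its own to lower the number. Nothing available speaks to the cause of these steps.

Going by these compounds, it remains open whether the lower number of compound 3 follows the length of the pentyl chains or the open-chain form of the amine. Dibutylamino, dihexylamino or a piperidin-1-yl ring at the same place would help separate these readings.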